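This account rests on a few compounds, and the source may have more. Where it says the series, first, only, none or still open, it means among the compounds named here.

Compound 1 `CC(C)N(Cc1cccc(OCCCCCC(=O)O)c1)C(=O)c1ccc(-c2cccc(Br)c2)cc1` carries a 3-bromophenyl group on a core that ends in a free carboxylic acid. In an ADME assay on BJ cells (Homo sapiens) for cytotoxicity, read by CellTiter-Glo and resazurin assay, with a stated time of 72 h (on this read-out lower numbers stand for an effect already at smaller amounts and higher numbers for an effect only at larger amounts of compound), compound 1 gives only a limit, > 26000 nM. Compound 2 `CC(C)N(Cc1cccc(OCCCCCC(=O)O)c1)C(=O)c1ccc(-c2ccc(Cl)c(Cl)c2)cc1` differs by 3,4-dichlorophenyl in place of 3-bromophenyl on an aromatic carbon. In this assay compound 2 likewise gives only a limit, > 26000 nM. The step that the two limits leave unreadable from compound 1 to compound 2 therefore cannot be read. Compound 3 `CCOC(=O)CCCCCOc1cccc(CN(C(=O)c2ccc(-c3cccc(Br)c3)cc2)C(C)C)c1` differs from compound 1 by ethyl in place of hydrogen on an oxygen next to a carbonyl group. In this assay compound 3 again gives only a limit, > 26000 nM. The step that the two limits leave unreadable from compound 1 to compound 3 is also not readable. Compound 4 `CCOC(=O)CCCCCOc1cccc(CN(C(=O)c2ccc(-c3ccc(Cl)c(Cl)c3)cc2)C(C)C)c1`, not yet measured, repeats on the core of compound 3 the same change, 3,4-dichlorophenyl in place of 3-bromophenyl on an aromatic carbon, at the same place as in the pair of compound 1 and compound 2. Within the data shown here, with all three values so far sitting at the limit (the limit of > 26000 nM in this assay, at which 3 of the 3 values shown sit), the step that the limit leaves unreadable from compound 3 to compound 4 is expected to remain unreadable, most likely a limit once more. For compound 4 the expected value is 40000 nM.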

Compound 4, half-maximal effective concentration: > 26000 nM
Compound 4 was reported as a limit; the forecaster's own chance of this, stated with the estimate: 85%; the middle value is on the limit's open side.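

No new step can be read from compound 4 against compound 3 or compound 2, because compound 4 and both partners are reported only as limits: the limit of > 26000 nM in this assay, at which 4 of the 4 values shown sit.

The compounds shown leave open whether 3,4-dichlorophenyl in place of 3-bromophenyl, or ethyl in place of hydrogen on the acid oxygen, changes the effect in this assay at all.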